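The source may hold more compounds than are shown below. What is called first, only, known or untested is meant among the compounds shown, and "the series" means these compounds.

Compound 1 `COc1ccc(CCCN2CCC(CO)CC2)cc1`: > 20000 nM
Compound 2 `COc1ccc(CCCN2CCC(COCc3ccc(Cl)cc3)CC2)cc1`: 500 nM
Compound 3 `COc1ccc(CCCN2CCC(COCc3ccccn3)CC2)cc1`: 5900 nM

All three values come from a functional assay on cells (T-cell line, Homo sapiens) for inhibition; a lower number here means a stronger inhibitor, a higher number a weaker inhibitor. Compound 1 gives > 20000 nM, which is a limit and not a number. Its standing in the set is therefore only this: the limit of > 20000 nM in this assay, at which 1 of the 3 values shown sits.

Compound 4 `COc1ccc(CCCN2CCC(COCC3CCCCC3)CC2)cc1` keeps the core of compound 1 and differs from it as follows: cyclohexylmethyl in place of hydrogen on an oxygen on a saturated carbon. In words, cyclohexylmethyl stands in place of hydrogen on an oxygen on a saturated carbon.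

Two measured steps make a change at the same oxygen. With 4-chlorobenzyl the result is an at least 40-fold lower number from compound 1 to compound 2 (1.60 log units; beyond the scatter). With (pyridin-2-yl)methyl the result is an at least 3.3-fold lower number from compound 1 to compound 3 (0.53 log units; beyond the scatter). The choice of group matters, as a 12-fold higher number from compound 2 to compound 3 (1.07 log units; beyond the scatter) shows.

A step toward a lower number is therefore expected in this assay, probably a large one. The ring of cyclohexylmethyl holds carbon only, so the expectation leans toward compound 2 at 500 nM, whose ring also lacks nitrogen, rather than compound 3 at 5900 nM. That leaning is weak, since no saturated ring has been measured here, so the range stays wide.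

The expected step is an at least 16-fold lower number from compound 1 to compound 4 (1.22 log units; beyond the scatter). The estimated value for compound 4 is 1200 nM, with an expected range of 300 nM to 5000 nM.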

Compound 4, half-maximal inhibitory concentration: 3000 nM
Compound 4: the middle estimate sits 2.5-fold (0.40 log units) below what was measured, and the stated range covers the measured number.
By their numbers in this assay, from the lowest: compound 2; then compounds 4 and 3 (each within the scatter of the next). At a limit, above all of these: compound 1.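

In this assay, cyclohexylmethyl on the oxygen also brings a gain over the free hydroxy compound, an at least 6.6-fold lower number from compound 1 to compound 4 (0.82 log units; beyond the scatter), so among the groups shown an aromatic ring is not required for a measurable value at this position. The 4-chlorophenyl and cyclohexyl ends are clearly separated, a 6.0-fold higher number from compound 2 to compound 4 (0.78 log units; beyond the scatter), whereas the cyclohexyl and pyridin-2-yl ends cannot be ordered, a 2.0-fold lower number from compound 3 to compound 4 (0.29 log units; within the scatter). Among the three ethers, only the 4-chlorobenzyl group stands apart, and the nitrogen-free ring of cyclohexylmethyl is not enough on its own to reach the value of compound 2, 500 nM.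

As far as these compounds go, the true size of the gain over the hydroxy compound remains open, since compound 1 gives only a limit: the limit of > 20000 nM in this assay, at which 1 of the 4 values shown sits. Also open is whether the advantage of compound 2 comes from the aromatic ring, the chlorine or the two together, a question that plain benzyl and 4-chlorocyclohexylmethyl on the same oxygen would address.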